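The source may report more compounds than this note shows. Statements on the series, on what has been measured and on what is new or still open speak of the compounds shown alone.

Measured in a functional assay (aorta) with Rattus norvegicus as the target; on this read-out lower numbers stand for stronger inhibition and higher numbers for weaker inhibition:
- compound 1 `CCCCN(CCCC)CCCCOc1ccc(S(=O)(=O)c2c(C(C)C)cn3ccccc23)cc1`: 20.2 nM
- compound 2 `CCCCN(CCCC)CCCOc1ccc(S(=O)(=O)c2c(CC)cn3ccccc23)cc1`: 31.3 nM
- compound 3 `CCCCCN(CCCCC)CCCOc1ccc(S(=O)(=O)c2c(CC)cn3ccccc23)cc1`: 62.4 nM

Compound 3 has the highest number of the three, but a 2.0-fold higher number from compound 2 to compound 3 (0.30 log units; within the scatter), so only compound 1 stands clearly apart from it. The next compound to be tested is compound 4 `CCCCN(CCCC)CCCCOc1ccc(S(=O)(=O)c2c(CC)cn3ccccc23)cc1`. It differs from compound 3 by a single change: (dibutylamino)methyl in place of dipentylamino on a saturated chain carbon, three bonds along the chain from an oxygen on an aromatic ring. In words, (dibutylamino)methyl replaces dipentylamino on a saturated chain carbon, three bonds along the chain from an oxygen on an aromatic ring.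

Going by the values given here, only one measured step touches this place, namely a 2.0-fold higher number from compound 2 to compound 3 (0.30 log units; within the scatter). The new group restores the dibutylamino part, so that step points towards a lower number, though it is small and lies within the scatter. Among the compounds with values here, the extra methyl part has no measured step of its own, which leaves the forecast loose. A small drop is therefore expected, and the expected change is a 2.0-fold lower number from compound 3 to compound 4 (0.29 log units; within the scatter). The estimate for compound 4 is 32 nM, with an expected range from 13 nM to 75 nM.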

Compound 4, half-maximal inhibitory concentration: 33.3 nM
Estimate against measurement, compound 4: 1.0-fold (0.02 log units) below, and the stated range covers the measured number.
By their numbers in this assay, from the lowest: compounds 1, 2, 4 and 3 (each within the scatter of the next, the first and the last beyond it).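

In this assay, the extra methyl part of (dibutylamino)methyl now has a measured step of its own, a 1.1-fold higher number from compound 2 to compound 4 (0.03 log units; within the scatter), so on this saturated chain carbon the readings for dibutylamino and (dibutylamino)methyl cannot be told apart. Putting (dibutylamino)methyl in place of dipentylamino gives a 1.9-fold lower number from compound 3 to compound 4 (0.27 log units; within the scatter), also within the scatter, so none of the three groups tried at this place stands clearly apart from the others. A second place gains a step as well: hydrogen in place of methyl on a saturated chain carbon bound to an aromatic carbon and a saturated chain carbon gives a 1.6-fold higher number from compound 1 to compound 4 (0.22 log units; within the scatter), again within the scatter.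

Nothing available offers a reason for these small steps. Going by these compounds, whether a much smaller amine such as dimethylamino, or a ring amine such as piperidine, would move the number beyond the scatter remains open.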